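Swapping one aryl group on compound 3

The source may hold more compounds than are shown below. What is called first, only, known or untested is meant among the compounds shown, and "the series" means these compounds.

Compound 1 `Cc1cc(-c2ccccc2F)cc(C)c1Oc1cc(N)nc(Nc2ccc(C#N)cc2)n1`: 29300 nM
Compound 2 `Cc1cc(-c2ccc(C#N)c(C#N)c2)cc(C)c1Oc1cc(N)nc(Nc2ccc(C#N)cc2)n1`: 17600 nM
Compound 3 `Cc1cc(-c2ccccc2F)ccc1Oc1cc(N)nc(Nc2ccc(C#N)cc2)n1`: 29500 nM

In a toxicity assay on MT4 cells (Homo sapiens) for cytotoxicity, read by MTT assay (a higher number here means that more compound is tolerated, a lower number that less compound is tolerated), compound 3 gives 29500 nM and sits within the scatter of both other compounds. Compound 4 `Cc1cc(-c2ccc(C#N)cc2)ccc1Oc1cc(N)nc(Nc2ccc(C#N)cc2)n1` carries one change from it: 4-cyanophenyl in place of 2-fluorophenyl on an aromatic carbon. The closest measured change is a 1.7-fold lower number from compound 1 to compound 2 (0.22 log units; within the scatter), where 3,4-dicyanophenyl took the place of 2-fluorophenyl. The other, a 1.0-fold higher number from compound 1 to compound 3 (0.00 log units; within the scatter), put hydrogen in place of methyl. The expected step is a 1.3-fold lower number from compound 3 to compound 4 (0.11 log units; within the scatter) and so none beyond the scatter. Compound 4 is estimated at 23000 nM and expected to fall between 11000 nM and 45000 nM.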

Compound 4, half-maximal cytotoxic concentration: 10400 nM
Beside the measured number, compound 4's estimate is 2.2-fold (0.34 log units) above it, outside the stated range (below it).
By their numbers in this assay, from the lowest: compounds 4, 2, 1 and 3 (each within the scatter of the next, the first and the last beyond it).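

For the compounds shown here, at this position, para to a large group, the choice of aryl group can shift the number in this assay: 4-cyanophenyl in place of 2-fluorophenyl gives a 2.8-fold lower number from compound 3 to compound 4 (0.45 log units; beyond the scatter), the only step in this set beyond the scatter. The swap to 3,4-dicyanophenyl, on the core with the second methyl, stayed within the scatter, at a 1.7-fold lower number from compound 1 to compound 2 (0.22 log units; within the scatter). Nothing measured here explains the step.

As far as these compounds go, whether 4-cyanophenyl would give the same step on the core of compound 1 stays open. So does the effect of an amine or a carboxylic acid on this aryl ring.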